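Adding a Cyanomethyl Group to a Ring Nitrogen

The compounds below may be only part of what the source reports. "The series", "measured", "known", "first", "only" and "open" are said of these compounds alone.

Of the compounds shown here, two have been measured in a physicochemical assay for solubility, read by LC-MS, in phosphate buffer, with a stated time of 24 h, at pH 7.4; on this read-out lower numbers stand for lower solubility and higher numbers for higher solubility. For the measured compounds named here, compound 1 `CN(c1ccccc1)c1cnc(NCc2c(F)ccc3c2CCO3)n2cnnc12` is the first. In this assay compound 1 gives < 2000 nM, which is a limit of the assay rather than a number. Compound 2 `Cc1ncccc1-c1cnc(NCc2c(F)ccc3c2CCO3)c2n[nH]c(=O)n12` carries a different core with the same side chain on the amine. In this assay compound 2 gives < 2000 nM, again a limit rather than a number. Compound 2 therefore stands at the floor of what this assay can report, as the limit of < 2000 nM in this assay, at which 2 of the 2 values shown sit, shows.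

Compound 3 `Cc1ncccc1-c1cnc(NCc2c(F)ccc3c2CCO3)c2nn(CC#N)c(=O)n12` differs from compound 2 in one place: cyanomethyl in place of hydrogen on an aromatic nitrogen. Going by the values given here, no measured pair of compounds differs in this way, so the size of the move is unknown. The step from compound 2 to compound 3 is expected to be a step that the limit leaves unreadable from compound 2 to compound 3, no larger than the usual scatter of this assay. Compound 3 is expected to give about 1000 nM in this assay, within a range from 300 nM to 3000 nM, and most likely only a limit will be reported again.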

Compound 3, solubility: 4000 nM
The estimate for compound 3 lay 4.0-fold (0.60 log units) below the measured number, and the stated range ends below it.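

In this assay compound 3 gives 4000 nM, a measured number rather than a limit, which neither earlier compound provided. The step for cyanomethyl in place of hydrogen on an aromatic nitrogen reads as an at least 2.0-fold higher number from compound 2 to compound 3 (0.30 log units; that floor lies within the scatter), so this position can carry the group and still give a readable value, although the printed floor alone does not show a change beyond the scatter. The true size of the step stays hidden because compound 2 gives only a limit of the assay: the limit of < 2000 nM in this assay, at which 2 of the 3 values shown sit.

With cyanomethyl as the only group shown on this nitrogen, it remains open whether the nitrile matters or whether any replacement for the hydrogen would read the same. A hydroxyethyl chain or a carboxylic acid at this nitrogen would help to separate those two possibilities.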